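Halogen exchange on the aniline ring of the thiourea series

The source may hold more compounds than are shown below. What is called first, only, known or untested is meant among the compounds shown, and "the series" means these compounds.

Compound 2 `Fc1ccc(NC(=S)Nc2nc3ccccc3s2)cc1` gives 32100 nM in a functional assay on U-937 cells (Homo sapiens) for cytotoxicity, read by MTT assay, with a stated time of 48 h (a lower number here means a stronger inhibitor, a higher number a weaker inhibitor), the higher of the two plain numbers available; the nearest is compound 1 `Fc1ccc(NC(=S)Nc2nc3ccc(F)cc3s2)cc1`, which in this assay gives 16200 nM, so that a 2.0-fold higher number from compound 1 to compound 2 (0.30 log units; within the scatter). Compound 3 `Fc1ccc(NC(=S)Nc2nc3c(Cl)cccc3s2)cc1` reaches only a limit in this assay, > 50000 nM. Its step, an at least 1.5-fold higher number from compound 2 to compound 3 (0.19 log units; that floor lies within the scatter), rests on that limit, (the limit of > 50000 nM in this assay, at which 1 of the 3 values shown sits).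

Compound 4 `S=C(Nc1ccc(Cl)cc1)Nc1nc2ccccc2s1` is not yet measured. Against compound 2 the change is chloro in place of fluoro on an aromatic carbon. Both measured steps concern a halogen on the other ring of the shared core, not the ring changed here, and neither moved the number beyond the scatter, one of them only toward a limit. On that basis no step beyond the scatter is expected in this assay for compound 4, with some chance that the number again ends as a limit. The estimate for compound 4 is 35000 nM, within 15000 nM to 80000 nM. The expected step is therefore a 1.1-fold higher number from compound 2 to compound 4 (0.04 log units; within the scatter).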

Compound 4, half-maximal inhibitory concentration: > 50000 nM
Compound 4 was reported as a limit; the forecaster's own chance of this, stated with the estimate: 35%; middle value at least 1.4-fold (0.15 log units) from the limit.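

Going by these compounds alone, compound 4 gives the first reading for a change on the ring carrying the fluoro group of compound 2, at the carbon para to a large group; the earlier steps concerned only the other ring of the shared core. Both steps that bring in chloro from compound 2, an at least 1.5-fold higher number from compound 2 to compound 3 (0.19 log units; that floor lies within the scatter) and an at least 1.5-fold higher number from compound 2 to compound 4 (0.19 log units; that floor lies within the scatter), end in a limit, so chloro at either place gives a floor and no size. Chloro and fluoro at this position cannot be ranked in this assay because the reading for compound 4 stops at a limit: the limit of > 50000 nM in this assay, at which 2 of the 4 values shown sit.

Going by these compounds, the true distance between compound 4 and compound 2 stays open. Also open, on these data alone, is how this position responds to a non-halogen group, such as an amine or a carboxylic acid.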